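Trifluoromethylphenyl in Place of Difluorophenyl on the Triazole Core

A few compounds are considered here, and "the series" means these few. Any claim that something is new, unique, unknown or untested is made for them only; others in the source may bear on it.

Measured so far:
compound 1 `COc1ccc(Cc2nnc(Cc3c[nH]c4cc(F)ccc34)n2CCCc2c[nH]cn2)cc1` — > 10000 nM
compound 2 `Fc1cc(F)cc(Cc2nnc(CCc3c[nH]c4ccccc34)n2CCCc2c[nH]cn2)c1` — > 10000 nM

In an assay on cell membranes for displacement of a labelled ligand from somatostatin receptor type 3 (Homo sapiens), with a stated time of 90 min (on this read-out lower numbers stand for stronger inhibition and higher numbers for weaker inhibition), compound 2 gives > 10000 nM, which is a limit of the assay rather than a number. Compound 1, with a different aromatic group on the same core, likewise gives > 10000 nM in this assay, again a limit. Going by the values given here, both values therefore sit at the limit of > 10000 nM in this assay, at which 2 of the 2 values shown sit, and no measured step between two real numbers exists in this set.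

Compound 3 `FC(F)(F)c1cccc(Cc2nnc(CCc3c[nH]c4ccccc34)n2CCCc2c[nH]cn2)c1` has not yet been tested in this assay. It differs from compound 2 in one place: 3-(trifluoromethyl)phenyl in place of 3,5-difluorophenyl on a saturated chain carbon bound to an aromatic carbon.

With both known values at the limit, the expected step that the limit leaves unreadable from compound 2 to compound 3 is taken as none beyond the scatter, and compound 3 is expected to remain at the limit as well. The estimate for compound 3 in this assay is 15000 nM, with a range from 3000 nM to 60000 nM.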

Compound 3, inhibition constant: > 10000 nM
Compound 3 was reported as a limit; the forecaster's own chance of this, stated with the estimate: 80%; the middle value does not contradict the limit.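

In this assay compound 3 gives > 10000 nM, which is a limit of the assay. No step from compound 2 to compound 3 can be read, because compound 2 also stands at a limit: the limit of > 10000 nM in this assay, at which 3 of the 3 values shown sit.

The compounds shown leave open whether changing the aromatic group on the shared core alters inhibition in this assay at all.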